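Swapping the ring on the side chain of compound 1

This account rests on a few compounds, and the source may have more. Where it says the series, first, only, none or still open, it means among the compounds named here.

Measured compounds:
compound 1 `CC(C)C(CC1C(=O)NC(=O)N1C)c1ccc(-c2ccc3cccc(F)c3c2)[nH]c1=O`: 65 nM
compound 3 `CCC(/C=C1\OC(=O)NC1=O)(CC)c1ccc(-c2ccc3cc(F)cc(F)c3c2)[nH]c1=O`: 45 nM
compound 2 `CCC(/C=C1\OC(=O)NC1=O)(CC)c1ccc(-c2ccc3cccc(C(C)C)c3c2)[nH]c1=O`: "not determined" (no result reported)

Two compounds have numbers in a functional assay on CHO cells for antagonist activity at prostaglandin E2 receptor EP3 subtype (Homo sapiens), read by cAMP accumulation, with a stated time of 30 min; a higher number here means a weaker inhibitor, a lower number a stronger inhibitor. Compound 1 gives 65 nM in this assay, the higher of the two numbers. Compound 3 gives 45 nM in this assay; the gap between compound 1 and compound 3 lies within the usual scatter, so the two cannot be told apart on this evidence. Compound 2 has no number in this assay; its entry reads "not determined" (no result reported).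

Compound 4 `C/C(=C1/OC(=O)NC1=O)C(c1ccc(-c2ccc3cccc(F)c3c2)[nH]c1=O)C(C)C` has not been measured. It differs from compound 1 in one place: a group of 9 heavy atoms (5 carbon, 1 nitrogen, 3 oxygen; one five-membered non-aromatic ring with 2 hetero atoms) in place of a group of 9 heavy atoms (5 carbon, 2 nitrogen, 2 oxygen; one five-membered non-aromatic ring with 2 hetero atoms), on a saturated chain carbon bound to an aromatic carbon and a saturated chain carbon. In words, a group of 9 heavy atoms (5 carbon, 1 nitrogen, 3 oxygen; one five-membered non-aromatic ring with 2 hetero atoms) replaces a group of 9 heavy atoms (5 carbon, 2 nitrogen, 2 oxygen; one five-membered non-aromatic ring with 2 hetero atoms), on a saturated chain carbon bound to an aromatic carbon and a saturated chain carbon.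

Among the compounds with values here, no pair of measured compounds shows this step on its own. Compound 3 carries the same kind of entering ring, yet also differs elsewhere, so it offers only a loose guide. Compound 4 is expected to sit close to compound 1, with the step from compound 1 to compound 4 estimated as a 1.3-fold lower number from compound 1 to compound 4 (0.11 log units; within the scatter), not beyond the scatter. The estimate for compound 4 in this assay is 50 nM, with a range from 15 nM to 170 nM.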

Compound 4, half-maximal inhibitory concentration: 39 nM
Compound 4: middle estimate off by 1.3-fold (0.11 log units), on the high side; measured number inside the range.
By their numbers in this assay, from the lowest: compounds 4, 3 and 1 (each within the scatter of the next).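

In this assay, placing the new ring group on this saturated chain carbon gives a 1.7-fold lower number from compound 1 to compound 4 (0.22 log units; within the scatter), so the two compounds cannot be told apart. Within the data shown here, this is the first comparison in which the side-chain group alone differs while the rest of the molecule stays the same. The entering group has one nitrogen fewer and one oxygen more than the (3-methyl-2,5-dioxoimidazolidin-4-yl)methyl group it replaces, and it has one more double bond outside aromatic rings, yet this single swap produces no difference that can be separated from the usual variation between repeated measurements, and no measurement at hand offers an explanation for this result.

The compounds shown leave open whether a carboxylic acid or an amine on this saturated chain carbon would also give a number in the same range. Also open, on these data alone, is whether this ring swap would give a similar result with other substituents on the shared core; compound 3 differs from compound 4 in more than one place and cannot settle that question.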